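This account rests on a few compounds, and the source may have more. Where it says the series, first, only, none or still open, it means among the compounds named here.

Compound 1 `Oc1cccc(-c2cc(-c3ccc(Cl)cc3)nc(-c3ccccn3)c2)c1`: 30%
Compound 2 `Oc1ccc(-c2cc(-c3ccncc3)nc(-c3ccc(Cl)cc3)c2)cc1`: 5.9%
Compound 3 `Oc1cccc(-c2cc(-c3ccccc3)nc(-c3ccc(Cl)cc3)c2)c1`: 7.1%

In an assay on isolated protein for inhibition of DNA topoisomerase 1 (Homo sapiens), with a stated time of 30 min, tested at 100 uM (a lower number here means a weaker effect, a higher number a stronger effect of the compound at the concentration tested), compound 3 stands second highest of the three numbers: compound 2 lies within the scatter of it, while compound 1 lies well above. Compound 4 `Oc1cccc(-c2cc(-c3ccncc3)nc(-c3ccc(Cl)cc3)c2)c1` is compound 3 with pyridin-4-yl in place of phenyl on an aromatic carbon. Within the data shown here, only one measured step bears on this kind of swap: a number 22.9 percentage points lower from compound 1 to compound 3 (beyond the scatter), where pyridin-2-yl gave way to phenyl. Compound 4 goes the other way, but with pyridin-4-yl rather than pyridin-2-yl, and compound 2, which also carries pyridin-4-yl, gives only 5.9%. The step is therefore expected to be a number 2.9 percentage points higher from compound 3 to compound 4 (within the scatter), not beyond the scatter. Compound 4 is estimated at 10%, within 0% to 28%.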

Compound 4, a percentage reported as inhibition, at one concentration (the size of the read-out at that concentration, not a potency): 8%
The estimate for compound 4 lay 2 percentage points above the measured number; low and high end bracket the measured number.
By their numbers in this assay, from the lowest: compounds 2, 3 and 4 (each within the scatter of the next); then compound 1.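

In this assay, a ring nitrogen in the pyridin-4-yl arrangement makes no difference at this position, a number 0.9 percentage points higher from compound 3 to compound 4 (within the scatter), and the hydroxyl's placement on the phenyl ring makes none with pyridin-4-yl present, a number 2.1 percentage points higher from compound 2 to compound 4 (within the scatter). The nitrogen's place within the ring does matter, a number 22 percentage points lower from compound 1 to compound 4 (beyond the scatter), so among these compounds only the pyridin-2-yl of compound 1 stands apart. No measurement here explains why.

Going by these compounds, whether pyridin-3-yl would side with pyridin-2-yl or with pyridin-4-yl remains open. So does the effect of an amine or a carboxylic acid at this position.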